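Thiazol-2-yl for thiophen-2-yl on the cyclobutylmethyl analogue

A few compounds are considered here, and "the series" means these few. Any claim that something is new, unique, unknown or untested is made for them only; others in the source may bear on it.

Measured so far in an in vitro ADME assay on microsomes from liver (Homo sapiens) for metabolic stability; on this read-out higher numbers stand for a longer-lived compound and lower numbers for a shorter-lived compound:
compound 1 `CC(C)CCn1nc(-c2cccs2)c(O)c(C2=NS(=O)(=O)c3cc(OCC(N)=O)ccc3N2)c1=O`: 0.383 h
compound 2 `NC(=O)COc1ccc2c(c1)S(=O)(=O)N=C(c1c(O)c(-c3cccs3)nn(CC3CCC3)c1=O)N2`: 0.367 h
compound 3 `NC(=O)COc1ccc2c(c1)S(=O)(=O)N=C(c1c(O)c(-c3cccs3)nn(CC3CCCC3)c1=O)N2`: 0.433 h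

The three numbers sit in a narrow band. Compound 2 carries the smaller figure, yet a 1.0-fold lower number from compound 1 to compound 2 (0.02 log units; within the scatter) and a 1.2-fold higher number from compound 2 to compound 3 (0.07 log units; within the scatter) are both within the scatter, as is a 1.1-fold higher number from compound 1 to compound 3 (0.05 log units; within the scatter). Across the three, the group on the saturated chain carbon bound to the aromatic nitrogen is the only thing varied, and this assay does not separate the isobutyl, cyclobutyl and cyclopentyl analogues.

Compound 4 `NC(=O)COc1ccc2c(c1)S(=O)(=O)N=C(c1c(O)c(-c3nccs3)nn(CC3CCC3)c1=O)N2` keeps the cyclobutylmethyl group of compound 2 and differs only as follows: 1,3-thiazol-2-yl in place of thiophen-2-yl on an aromatic carbon. Within the data shown here, no measured step touches this aromatic position, so nothing here bears on the change directly; the measured steps only show that the shared core holds this assay close to the same figure under small changes. The expected size of step is therefore none beyond the scatter, that is a 1.0-fold higher number from compound 2 to compound 4 (0.00 log units; within the scatter). Compound 4 is estimated at 0.37 h in this assay, with a range from 0.18 h to 0.75 h.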

Compound 4, half-life: > 1 h
Compound 4: no number, only a limit; the forecaster's own chance of this, stated with the estimate: 0%; at least 2.7-fold (0.43 log units) between middle value and limit.
By their numbers in this assay, from the lowest: compounds 2, 1 and 3 (each within the scatter of the next). At a limit, above all of these: compound 4.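

In this assay, 1,3-thiazol-2-yl in place of thiophen-2-yl on the cyclobutylmethyl analogue gives an at least 2.7-fold higher number from compound 2 to compound 4 (0.43 log units; beyond the scatter). This aromatic carbon, next to the ring nitrogen, is therefore a place where a change of one ring atom moves the read-out beyond the scatter, something the steps among compound 1, compound 2 and compound 3 did not show for the group on the saturated chain carbon. Compound 4 stands at a limit and not at a number, so the step has a lower bound only: the limit of > 1 h in this assay, at which 1 of the 4 values shown sits.

Whether the step carries over to the isobutyl and cyclopentyl analogues stays open, as does the reason for it. On these data alone, how a pyridin-2-yl or phenyl ring would read at this aromatic carbon is also open.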